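Trimming the benzylic amine substituent on the shared core

The source may report more compounds than this note shows. Statements on the series, on what has been measured and on what is new or still open speak of the compounds shown alone.

Compound 1 `CCC[C@@H](CCO)Nc1nc(N)nc(C)c1Cc1ccc(CN(C)CC(N)=O)cc1OC` is the parent of this pair. In an assay on HEK293 cells for agonist activity at Toll-like receptor 8 (Homo sapiens) (on this read-out higher numbers stand for an effect only at larger amounts of compound and lower numbers for an effect already at smaller amounts), compound 1 gives only the limit > 10000 nM, so where compound 1 stands is known as a limit only (the limit of > 10000 nM in this assay, at which 2 of the 2 values shown sit). Compound 2 `CCC[C@@H](CCO)Nc1nc(N)nc(C)c1Cc1ccc(CNCC(N)=O)cc1OC` is the analogue with hydrogen in place of methyl on the amine nitrogen. In this assay compound 2 likewise gives the limit > 10000 nM. The step that the two limits leave unreadable from compound 1 to compound 2 therefore cannot be read. Compound 3 `CCC[C@@H](CCO)Nc1nc(N)nc(C)c1Cc1ccc(CNC)cc1OC` carries the change hydrogen in place of carbamoylmethyl on an amine nitrogen against compound 1. Going by the values given here, only that unreadable step bears on it, so no size or direction of step in this assay can be expected beyond the scatter, and a limit again is the likely outcome. Compound 3 is estimated at 15000 nM, range 3000 nM to 80000 nM. The expected step is a step that the limit leaves unreadable from compound 1 to compound 3.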

Compound 3, half-maximal effective concentration: 6460 nM
Beside the measured number, compound 3's estimate is 2.3-fold (0.37 log units) above it, within the range that was stated.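

Working notes: with carbamoylmethyl replaced by hydrogen on the amine nitrogen, compound 3 gives the first number in the series that is not a limit in this assay, namely 6460 nM. The readable steps are an at least 1.5-fold lower number from compound 1 to compound 3 (0.18 log units; that floor lies within the scatter) and an at least 1.5-fold lower number from compound 2 to compound 3 (0.18 log units; that floor lies within the scatter), so each is only a floor and neither shows a change beyond the scatter. Compound 1 and compound 2 remain limits, and the step between them cannot be read: the limit of > 10000 nM in this assay, at which 2 of the 3 values shown sit.

From the compounds shown here alone, the true size of both steps stays open. Also open, going by these compounds, is how a primary amine, or a longer chain such as ethyl in place of the remaining methyl, would read at this nitrogen.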